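Furan in Place of Methoxy: Cytotoxicity Expectation

This account rests on a few compounds, and the source may have more. Where it says the series, first, only, none or still open, it means among the compounds named here.

Compound 2 `COc1cccc(C(=O)N2CCCC(C(=O)Nc3ccc(Cl)cc3)C2)c1` belongs to a small set of amide-linked compounds tested for their effect on cell viability. In an ADME assay on PC-3 cells (Homo sapiens) for cytotoxicity, read by WST assay, tested at 100 uM (on this read-out higher numbers stand for more inhibition at the one concentration tested (going by the name of the read-out) and lower numbers for less inhibition), compound 2 gives 0%, a reading at the same level as its nearest neighbour. That neighbour, compound 1 `C=Cc1cccc(C(=O)N2CCCC(C(=O)Nc3ccc(Cl)cc3)C2)c1`, carries a vinyl group where compound 2 carries a methoxy group, and in this assay compound 1 gives 0%. Within the data shown here, the one step already measured, no change at the digits printed from compound 1 to compound 2 (within the scatter), shows that exchanging these two small groups on the aromatic ring left the reading unchanged.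

Compound 3 `O=C(Nc1ccc(Cl)cc1)C1CCCN(C(=O)c2cccc(-c3ccco3)c2)C1` is the next compound in line. It differs from compound 2 by a single replacement: furan-2-yl in place of methoxy on an aromatic carbon. Among the measured compounds shown here, the one measured step bears on this change only in a general way, since it also alters a group on the same aromatic carbon, and it was flat. On that basis the expected step of a number 5 percentage points higher from compound 2 to compound 3 (within the scatter) is none beyond the scatter. For compound 3 the estimated reading in this assay is 5%, with a range from 0% to 25%, resting on compound 2 at 0%.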

Compound 3, a percentage reported as inhibition, at one concentration (the size of the read-out at that concentration, not a potency): 0%
Estimate against measurement, compound 3: 5 percentage points above, within the range that was stated.
By their numbers in this assay, from the lowest: compounds 1, 2 and 3 (each within the scatter of the next).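

In this assay, putting furan-2-yl in place of methoxy gives no change at the digits printed from compound 2 to compound 3 (within the scatter), and putting it in place of vinyl gives no change at the digits printed from compound 1 to compound 3 (within the scatter). Among these compounds, the earlier pair showed only that one small group could replace another on this aromatic carbon, meta to a large group, without moving the reading. Compound 3 extends that observation to a group of 5 heavy atoms that brings in a five-membered aromatic ring, and nothing available explains why the reading stays flat across these three groups.

All three compounds read the same at the one concentration tested, so this series does not yet show whether any group at this place can raise the inhibition seen in this assay. An amine, a carboxylic acid or a longer chain on this same aromatic carbon would be a different kind of test, and the compounds shown leave open whether such a group, or a change elsewhere on the shared core, would give a reading that differs from these.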